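The source may hold more compounds than are shown below. What is called first, only, known or untested is meant among the compounds shown, and "the series" means these compounds.

Two measured compounds share one core here: compound 1 `CCO/N=C1/C(=O)N(Cc2cn(CC(=O)N3CCN(c4cc5c(cc4F)c(=O)c(C(=O)O)cn5C4CC4)CC3)nn2)c2ccccc21` and compound 2 `CO/N=C1/C(=O)N(Cc2cn(CC(=O)N3CCN(c4cc5c(cc4F)c(=O)c(C(=O)O)cn5C4CC4)CC3)nn2)c2ccc(F)cc21`. In an ADME assay on Vero cells (Chlorocebus sabaeus) for cytotoxicity (on this read-out lower numbers stand for higher toxicity in this test and higher numbers for lower toxicity in this test), compound 1 gives 64 ug/mL and compound 2 gives 64 ug/mL, so compound 2 stands level with compound 1, within the scatter of repeated measurements. Compound 3 `CCO/N=C1/C(=O)N(Cc2cn(CC(=O)N3CCN(c4cc5c(cc4F)c(=O)c(C(=O)O)cn5C4CC4)CC3)nn2)c2ccc(F)cc21` has not yet been measured. It comes from compound 2 through one small edit: methyl in place of hydrogen on a saturated chain carbon bound to an oxygen on an unsaturated carbon. In words, this is methyl in place of hydrogen on a saturated chain carbon bound to an oxygen on an unsaturated carbon, so methoxy becomes ethoxy. For the measured compounds named here, no measured pair in this small set shows this edit alone, so its size cannot be read directly. Still, compound 1 also carries ethoxy and gives 64 ug/mL, which offers no hint of a shift. In this assay no step beyond the scatter is expected, in either direction. The estimate therefore means an expected no change at the digits printed from compound 2 to compound 3 (within the scatter). For compound 3 the expected value is 64 ug/mL, with an estimated range from 32 ug/mL to 128 ug/mL.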

Compound 3, half-maximal cytotoxic concentration: 8 ug/mL
The estimate for compound 3 lay 8.0-fold (0.90 log units) above the measured number; measured number outside the range, below it.
By their numbers in this assay, from the lowest: compound 3; then compounds 1 and 2 (each within the scatter of the next).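

In this assay, the step from methoxy to ethoxy is not silent at this place on the chain: adding one methyl gives an 8.0-fold lower number from compound 2 to compound 3 (0.90 log units; beyond the scatter). The fluoro on the aromatic carbon also matters, as fluoro in place of hydrogen gives an 8.0-fold lower number from compound 1 to compound 3 (0.90 log units; beyond the scatter), so compound 3, the only one of the three that carries both ethoxy and fluoro, stands apart from the other two, and each edit shows its step only with the other already present. No measurement here offers an explanation for this drop.

For the compounds shown here, the set holds no compound with methoxy and hydrogen in place of fluoro, so it remains unknown whether each edit would lower the number on its own or whether the drop needs the two together. Also open, on these data alone, is how far the trend runs at either place, for example whether a longer chain such as propoxy would lower the number further, or whether chloro in place of fluoro would give a similar step.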